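This account rests on a few compounds, and the source may have more. Where it says the series, first, only, none or still open, it means among the compounds named here.

Measured compounds:
Compound 1 `C#CCN(C)CCCCCCOc1ccc2c(c1)OCC2=O` gives 51.9 nM in an assay on BTI cells for inhibition of Amine oxidase [flavin-containing] B (Homo sapiens), read by fluorescence and Amplex Red, with a stated time of 15 min; a lower number here means a stronger inhibitor, a higher number a weaker inhibitor.
Compound 2 `C#CCN(C)CCCCCCOc1ccc2c(c1)CCCC2=O` gives 133 nM in this assay.
Compound 3 `C#CCN(C)CCCOc1ccc2c(c1)OCCC2=O` gives 11400 nM in this assay.

Compound 3 stands at the highest of the three numbers, and therefore as the weakest inhibitor of the set. Its gap to compound 2 lies beyond the scatter, and the still larger gap to compound 1 lies beyond it as well. Compound 3 is also the one whose chain between the amine and the aromatic oxygen is the shortest of the three.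

Compound 4 `C#CCN(C)CCCCCOc1ccc2c(c1)OCCC2=O` has not yet been measured in this assay. It differs from compound 3 in one place: 2-(methyl(propargyl)amino)ethyl in place of methyl(propargyl)amino on a saturated chain carbon, three bonds along the chain from an oxygen on an aromatic ring. The chain from the amine to the aromatic oxygen is thereby longer in compound 4 than in compound 3, and closer in length to that of compounds 1 and 2. For the measured compounds named here, since no pair of measured compounds differs in exactly this way, the step itself is not known.

The expectation rests on compound 1, which with a longer chain gives 51.9 nM, and on compound 2, which gives 133 nM. On that basis the step of a 23-fold lower number from compound 3 to compound 4 (1.36 log units; beyond the scatter) is expected to be large and toward a lower number, well beyond the scatter. For compound 4 the estimate in this assay is 500 nM, with a range from 100 nM to 3000 nM.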

Compound 4, half-maximal inhibitory concentration: 4 nM
For compound 4 the middle estimate is 130-fold (2.10 log units) above the measured one; the whole stated range lies above it.
By their numbers in this assay, from the lowest: compound 4; then compound 1; then compound 2; then compound 3.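

In this assay, putting 2-(methyl(propargyl)amino)ethyl in place of methyl(propargyl)amino, on a saturated chain carbon, three bonds along the chain from an oxygen on an aromatic ring, gives a 2900-fold lower number from compound 3 to compound 4 (3.45 log units; beyond the scatter) on an otherwise unchanged core. For the compounds shown here, this is the first pair in the set that differs in one place, so the effect of chain length on this core now stands as a direct measurement, whereas compound 1 and compound 2 differ from compound 4 in more than one place and cannot isolate it. The two groups match in nitrogen, triple bonds, hydrogen-bond donors and acceptors and in having no ring, and differ only in carbon count, 4 against 6, so a change confined to the chain is enough for a step of this size at this position.

No measurement shown here explains why the step is so large. Going by these compounds alone, with only two chain lengths on this core, it remains open whether a still longer chain would hold, improve or lose this level of inhibition, and whether an ethyl group in place of the methyl on the amine would be tolerated.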